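The source may hold more compounds than are shown below. What is called first, only, known or untested is meant among the compounds shown, and "the series" means these compounds.

Measured so far in an assay on CHO cells for displacement of a labelled ligand from adenosine receptor A3 (Homo sapiens), read by scintillation counting, with a stated time of 120 min, tested at 1 uM; a lower number here means less inhibition, a higher number more inhibition at the concentration tested (going by the name of the read-out):
- compound 1 `N#Cc1c(N)nc(SCc2nc3ccccc3[nH]2)c(C#N)c1-c1ccc(OCC2CC2)cc1`: 1%
- compound 2 `C=CCOc1ccc(-c2c(C#N)c(N)nc(SCc3ccn[nH]3)c2C#N)cc1`: 13%

In this assay compound 1 gives 1%, the lowest of the two numbers. The nearest, compound 2, gives 13%, a value that lies beyond the scatter above compound 1. Within the data shown here, the two differ in more than one place, so no single step between measured compounds is available; the pair shows only that compound 2 sits higher.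

Compound 3 `N#Cc1c(N)nc(SCC(=O)NO)c(C#N)c1-c1ccc(OCC2CC2)cc1` is not yet measured. It differs from compound 1 in one place: hydroxycarbamoyl in place of 1H-benzimidazol-2-yl on a saturated chain carbon bound to a sulfur. The sulfur-linked saturated chain carbon on the shared core stays; a two-ring group leaves and a ring-free group enters.

Among the measured compounds shown here, with no measured step to lean on, the expectation rests on where compound 1 sits. Because compound 1 gives 1%, the expected step is a number 4 percentage points higher from compound 1 to compound 3 (within the scatter), small and within the scatter, with no firm direction. Compound 3 is expected at 5%, with a range from -8% to 20%.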

Compound 3, a percentage reported as inhibition, at one concentration (the size of the read-out at that concentration, not a potency): 31%
The estimate for compound 3 lay 26 percentage points below the measured number; measured number above the stated range.
By their numbers in this assay, from the lowest: compound 1; then compound 2; then compound 3.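

Among these compounds, at the saturated chain carbon bound to a sulfur, the two-ring 1H-benzimidazol-2-yl group is not required for the read-out in this assay: replacing it with hydroxycarbamoyl gives a number 30 percentage points higher from compound 1 to compound 3 (beyond the scatter), the first single-place step. The position therefore accepts a ring-free group with fewer heavy atoms, and the number rises beyond the scatter. No measurement available here accounts for this rise.

Going by these compounds, it remains open whether the step belongs to hydroxycarbamoyl specifically or would also appear with another small ring-free group, such as a carboxylic acid or a primary carboxamide on the same saturated chain carbon. Also open, on these data alone, are whether the step carries over to the other aryl ether substituent seen in compound 2 and what potency lies behind these single-concentration percentages.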